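Aryl swaps at the sulfanylmethyl group: outlook for compound 4

The source may report more compounds than this note shows. Statements on the series, on what has been measured and on what is new or still open speak of the compounds shown alone.

Measured so far:
compound 1 `N#Cc1c(N)nc(SCc2cccc(C(N)=O)c2)c(C#N)c1-c1ccc(OCC2CC2)cc1` — 1%
compound 2 `N#Cc1c(N)nc(SCc2ncn[nH]2)c(C#N)c1-c1ccc(OCC2CC2)cc1` — 1%
compound 3 `N#Cc1c(N)nc(SCn2cncn2)c(C#N)c1-c1ccc(OCC2CC2)cc1` — 1%

In an assay on CHO cells for displacement of a labelled ligand from adenosine receptor A3 (Homo sapiens), read by scintillation counting, with a stated time of 120 min, tested at 1 uM (a higher number here means more inhibition at the concentration tested (going by the name of the read-out), a lower number less inhibition), compound 3 gives 1%, level with compounds 1 and 2. The steps of no change at the digits printed from compound 1 to compound 2 (within the scatter), no change at the digits printed from compound 1 to compound 3 (within the scatter) and no change at the digits printed from compound 2 to compound 3 (within the scatter) all stay within the scatter, so three different groups on the saturated chain carbon bound to a sulfur have left the read-out unchanged.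

Compound 4 `N#Cc1c(N)nc(SCc2cccnc2)c(C#N)c1-c1ccc(OCC2CC2)cc1` differs from compound 3 as follows: pyridin-3-yl in place of 1H-1,2,4-triazol-1-yl on a saturated chain carbon bound to a sulfur. Within the data shown here, the same place is varied as in every step so far, none of which moved the read-out; no step beyond the scatter is therefore expected here, and a number 1 percentage points higher from compound 3 to compound 4 (within the scatter) is estimated to sit within it.

For compound 4 the expected value in this assay is 2%, with a range from -8% to 14%.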

Compound 4, a percentage reported as inhibition, at one concentration (the size of the read-out at that concentration, not a potency): 19%
Compound 4: the middle estimate sits 17 percentage points below what was measured, outside the stated range (above it).
By their numbers in this assay, from the lowest: compounds 1, 2 and 3 (each within the scatter of the next); then compound 4.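

In this assay, the number does move at the saturated chain carbon bound to a sulfur: pyridin-3-yl gives a number 18 percentage points higher from compound 3 to compound 4 (beyond the scatter), and also a number 18 percentage points higher from compound 2 to compound 4 (beyond the scatter) and a number 18 percentage points higher from compound 1 to compound 4 (beyond the scatter). The level readings of compounds 1, 2 and 3 therefore did not show that the number stays level for every group at this place. Nothing available accounts for the separation of pyridin-3-yl from the other groups.

Still open, going by these compounds, is how a plain phenyl or a pyridin-4-yl would read at the same place. With one concentration only, the potency of compound 4 also remains undefined.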